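Acylguanidine series: hydrogen in place of the anilino group

The compounds below may be only part of what the source reports. "The series", "measured", "known", "first", "only" and "open" are said of these compounds alone.

Compound 1 `Cc1cc(-c2ccco2)c(S(C)(=O)=O)cc1C(=O)N=C(N)N`, compound 2 `Cc1cc(O)c(S(C)(=O)=O)cc1C(=O)N=C(N)N` and compound 3 `Cc1cc(Nc2ccccc2)c(S(C)(=O)=O)cc1C(=O)N=C(N)N` share one core. In a functional assay for inhibition of sodium/hydrogen exchanger (Oryctolagus cuniculus) (on this read-out higher numbers stand for weaker inhibition and lower numbers for stronger inhibition), compound 1 gives 16 nM, compound 2 gives 220 nM and compound 3 gives 21 nM. Compound 3 thus stands close to compound 1 and well apart from compound 2. Compound 4 `Cc1ccc(S(C)(=O)=O)cc1C(=O)N=C(N)N` carries hydrogen in place of anilino on an aromatic carbon. Among the compounds with values here, no measured step removes a substituent altogether; the nearest guides are a 10-fold lower number from compound 2 to compound 3 (1.02 log units; beyond the scatter) and a 14-fold higher number from compound 1 to compound 2 (1.14 log units; beyond the scatter), while a 1.3-fold higher number from compound 1 to compound 3 (0.12 log units; within the scatter) shows furan-2-yl and anilino giving like numbers. Removing the substituent is expected to cost roughly as much as the exchange for hydroxy did. Accordingly the step of a 14-fold higher number from compound 3 to compound 4 (1.15 log units; beyond the scatter) is expected in this assay. Compound 4 is estimated at 300 nM, range 80 nM to 1200 nM.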

Compound 4, half-maximal inhibitory concentration: 150 nM
Compound 4: the middle estimate sits 2.0-fold (0.30 log units) above what was measured, and the stated range covers the measured number.
By their numbers in this assay, from the lowest: compounds 1 and 3 (each within the scatter of the next); then compounds 4 and 2 (each within the scatter of the next).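

In this assay, hydrogen on this aromatic carbon, ortho to a methylsulfonyl group, gives a baseline against which both anilino (a 7.1-fold higher number from compound 3 to compound 4 (0.85 log units; beyond the scatter)) and furan-2-yl (a 9.4-fold higher number from compound 1 to compound 4 (0.97 log units; beyond the scatter)) show a gain. Hydroxy shows no gain over hydrogen (a 1.5-fold lower number from compound 2 to compound 4 (0.17 log units; within the scatter)). No measurement bears on the reason for this difference.

The compounds shown leave open whether the gain requires an aromatic ring at this position, a question that a dimethylamino group or a short alkyl chain could address. Also open, going by these compounds, is whether substituents on the anilino ring change the number further.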